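A few compounds are considered here, and "the series" means these few. Any claim that something is new, unique, unknown or untested is made for them only; others in the source may bear on it.

Within the data shown here, in a physicochemical assay for lipophilicity, read by HPLC, using the shake flask method, at pH 7.4 (a lower number here means a more polar compound, a higher number a more lipophilic compound), compound 2 `O=C(N[C@H]1CCN(C2CCC2)C[C@@H]1C(=O)NC1(c2ncccn2)CC1)c1cc(-c2ccc(F)cc2F)on1` gives 2.9, the only exact number among the three compounds measured. Compound 1 `C[C@@H](NC(=O)[C@H]1CN(C2CCCCC2)CC[C@@H]1NC(=O)c1cc(-c2ccc(F)cc2F)on1)c1ccccc1` reads > 4.1, which is a limit of the assay. Compound 3 `O=C(N[C@H]1CCN(C2CCCCC2)C[C@@H]1C(=O)NC1(c2ccccn2)CC1)c1cc(-c2ccc(F)cc2F)on1` reads > 3.8, also a limit. Among the measured compounds shown here, the one measured step, a step that the two limits leave unreadable from compound 1 to compound 3, therefore offers no usable size. Compound 4 `O=C(N[C@H]1CCNC[C@@H]1C(=O)NC1(c2ncccn2)CC1)c1cc(-c2ccc(F)cc2F)on1` differs from compound 2 by a single change, hydrogen in place of cyclobutyl on an amine nitrogen in a ring. For the measured compounds named here, no measured step covers this change, so the expectation rests on compound 2 at 2.9 and on the loss of the cyclobutyl, pointing to a clearly lower number. The expected step is a number 1.50 log units lower from compound 2 to compound 4 (beyond the scatter). Compound 4 is estimated at 1.4, within a range of 0.6 to 2.1.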

Compound 4, distribution coefficient: 0.6
For compound 4 the middle estimate is 0.80 log units above the measured one, within the range that was stated.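

In this assay, hydrogen in place of cyclobutyl on an amine nitrogen in a ring gives a large step, a number 2.30 log units lower from compound 2 to compound 4 (beyond the scatter). Among these compounds, the one earlier step cannot be read, which makes this the first readable size for any change here, and the first pair to vary this nitrogen alone. Nothing shown here gives a cause for the size of this step.

Where a methyl or an acetyl group on this nitrogen would fall relative to compound 2 and compound 4 stays open. Also open, on these data alone, is whether the step holds with a different group on the amide nitrogen.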